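Dropping the tert-butyl: one change, two pairs of compounds

A few compounds are considered here, and "the series" means these few. Any claim that something is new, unique, unknown or untested is made for them only; others in the source may bear on it.

Compound 1 `Cc1c(OCCCCOc2ccc(C(=O)CC(C)(C)C)c(O)c2C)cccc1C(=O)O` and compound 3 `CC(=O)c1ccc(OCCCCOc2cccc(C(=O)O)c2C)c(C)c1O` share one core, while compound 2 `COc1cc(C(=O)O)ccc1OCCCCOc1ccc(C(=O)CC(C)(C)C)c(O)c1C` and compound 4 `COc1cc(C(=O)O)ccc1OCCCCOc1ccc(C(C)=O)c(O)c1C` share another; the difference between the two cores is not broken down here. In an assay on HEK293 cells for positive allosteric modulation of metabotropic glutamate receptor 2 (Rattus norvegicus), read by thallium flux, with a stated time of 2.5 min (on this read-out lower numbers stand for smaller maximal responses and higher numbers for larger maximal responses), compound 1 reaches 95.8%, and compound 3 reaches 79.2%. These two differ by a single change, hydrogen in place of tert-butyl on a saturated chain carbon bound to a carbonyl carbon and that change gave a number 16.6 percentage points lower from compound 1 to compound 3 (beyond the scatter). In this assay compound 2 gives 98.6%; against compound 1 it stands within the usual scatter of such measurements, while its gap to compound 3 lies beyond that scatter. Compound 4 has not yet been measured. It carries the same change as the earlier pair, hydrogen in place of tert-butyl on a saturated chain carbon bound to a carbonyl carbon made in the core of compound 2 rather than that of compound 1. Going by the values given here, with only one earlier example of this change, the plainest expectation is that the step repeats in size. For compound 4 the expected step is a number 16.6 percentage points lower from compound 2 to compound 4 (beyond the scatter), and it rests on a number 16.6 percentage points lower from compound 1 to compound 3 (beyond the scatter). Compound 4 is therefore estimated to reach 82%, with a likely range from 70% to 95%.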

Compound 4, largest response reached (reported as percent of maximum), in percent of the reference or control that the assay uses: 86.3%
For compound 4 the middle estimate is 4.3 percentage points below the measured one; the measured number falls inside the stated range.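

In this assay, putting hydrogen in place of tert-butyl on the core of compound 2 gave a number 12.3 percentage points lower from compound 2 to compound 4 (beyond the scatter), so the drop seen on the core of compound 1 appeared again. The two steps agree as closely as measurements of this kind can show: the same change on two cores in this assay, a number 16.6 percentage points lower (beyond the scatter) from compound 1 to compound 3 and a number 12.3 percentage points lower (beyond the scatter) from compound 2 to compound 4, 4.3 percentage points apart, within the scatter of two such steps This suggests that, between these two cores, the change can be carried across with its direction and approximate size intact, but two pairs say nothing about a third core and do not explain why the maximal response falls.

On these data alone, only tert-butyl and hydrogen appear at this place, so it remains open how a group of intermediate size, such as isopropyl, or a different kind of group, such as an amine or a phenyl ring, would behave there. As far as these compounds go, all four compounds also carry a carboxylic acid, so it is unknown whether the step would hold with a tetrazole in its place.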